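The Same Swap, Chloro to Nitro, Tried a Second Time

The source may hold more compounds than are shown below. What is called first, only, known or untested is meant among the compounds shown, and "the series" means these compounds.

Compound 1 `CN1CCN(c2ccc(S(=O)(=O)Oc3cccc(Cl)c3)cc2)C1=O` opens this set. In a functional assay on MCF7 cells (Homo sapiens) for antiproliferative activity, read by sulforhodamine B assay, with a stated time of 48 h (on this read-out lower numbers stand for stronger inhibition and higher numbers for weaker inhibition), compound 1 gives 2200 nM. Compound 2 `CN1CCN(c2ccc(S(=O)(=O)Oc3cccc([N+](=O)[O-])c3)cc2)C1=O` carries nitro in place of chloro on an aromatic carbon. In this assay compound 2 reaches only a limit of the measurement, > 100000 nM, which is the limit of > 100000 nM in this assay, at which 1 of the 3 values shown sits. The step is an at least 45-fold higher number from compound 1 to compound 2 (1.65 log units; beyond the scatter). Compound 3 `CCCN1CCN(c2ccc(S(=O)(=O)Oc3cccc(Cl)c3)cc2)C1=O` is the second variation on compound 1. In this assay compound 3 gives 380 nM, a step of a 5.8-fold lower number from compound 1 to compound 3 (0.76 log units; beyond the scatter), and this leaves compound 3 with the lowest of the two numbers that are numbers.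

Compound 4 `CCCN1CCN(c2ccc(S(=O)(=O)Oc3cccc([N+](=O)[O-])c3)cc2)C1=O` has not yet been measured. It differs from compound 3 by nitro in place of chloro on an aromatic carbon, the same change that separates compound 1 from compound 2, made at the same place in both cases; among the compounds shown it appears at two places. The two cores differ from one another by ethyl in place of hydrogen on a saturated chain carbon bound to an amide-type nitrogen in a ring.

The expected step here is a 110-fold higher number from compound 3 to compound 4 (2.02 log units; beyond the scatter). That expectation rests on the earlier, very large step an at least 45-fold higher number from compound 1 to compound 2 (1.65 log units; beyond the scatter), applied to the value of compound 3, 380 nM. Compound 4 is accordingly estimated at 40000 nM in this assay, within a range from 10000 nM to 100000 nM, with a real chance that, as for compound 2, only a limit is reported.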

Compound 4, half-maximal inhibitory concentration: 19000 nM
The estimate for compound 4 lay 2.1-fold (0.32 log units) above the measured number; the measured number falls inside the stated range.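

In this assay the change from 3-chlorophenyl to 3-nitrophenyl, carried over to the core of compound 3, again moves the number upward, giving a 50-fold higher number from compound 3 to compound 4 (1.70 log units; beyond the scatter), and set beside the first case it reads: the same change on two cores in this assay, an at least 45-fold higher number (1.65 log units; beyond the scatter) from compound 1 to compound 2 and a 50-fold higher number (1.70 log units; beyond the scatter) from compound 3 to compound 4; the limit leaves it open whether they differ The other change between the cores, ethyl in place of hydrogen, also keeps its direction when read on the nitro pair, giving an at least 5.2-fold lower number from compound 2 to compound 4 (0.72 log units; beyond the scatter), and the comparison with the chloro pair reads: the same change on two cores in this assay, a 5.8-fold lower number (0.76 log units; beyond the scatter) from compound 1 to compound 3 and an at least 5.2-fold lower number (0.72 log units; beyond the scatter) from compound 2 to compound 4; the limit leaves it open whether they differ Compound 2 is known only as a limit, so the series shows a shared direction on two cores and a large step on each, but it does not show that the steps are equal, and two cores are too few to speak for any others: the limit of > 100000 nM in this assay, at which 1 of the 4 values shown sits.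

The compounds shown leave open how an amine, a nitrile or a methoxy group would compare with chloro and nitro on the same aromatic carbon. They also leave open whether the change from chloro to nitro would carry over in the same way to a core with a longer chain than that of compound 3.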